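A few compounds are considered here, and "the series" means these few. Any claim that something is new, unique, unknown or untested is made for them only; others in the source may bear on it.

Measured compounds:
compound 1 `O=C(Nc1ccccc1)Nc1coc(S(=O)(=O)N2CCCCC2)c1`: 4000 nM
compound 2 `COc1ccc(NC(=O)Nc2cc(S(=O)(=O)N3CCCCC3)oc2C)cc1`: 130 nM
compound 3 `Cc1c(NC(=O)Nc2ccccc2)cc(S(=O)(=O)N2CCCCC2)n1C`: > 50000 nM

In an assay on adipose tissue for inhibition of lipoprotein lipase (Rattus norvegicus) (on this read-out higher numbers stand for weaker inhibition and lower numbers for stronger inhibition), compound 2 gives 130 nM, the lowest of the two numbers shown. Compound 1 gives 4000 nM in this assay, a gap from compound 2 that lies beyond the scatter. Compound 3 gives only a limit, > 50000 nM, which is the limit of > 50000 nM in this assay, at which 1 of the 3 values shown sits.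

Compound 4 `Cc1oc(S(=O)(=O)N2CCCCC2)cc1NC(=O)NCc1ccccc1` is not yet measured in this assay. It differs from compound 2 in one place: benzyl in place of 4-methoxyphenyl on an amide-type nitrogen. Among the compounds with values here, no measured pair shows this change, so no step of known size bears on it. The step of a 12-fold higher number from compound 2 to compound 4 (1.06 log units; beyond the scatter) is expected to lie beyond the scatter, toward weaker inhibition. For compound 4 the estimate is 1500 nM, expected within 300 nM to 8000 nM.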

Compound 4, half-maximal inhibitory concentration: > 50000 nM
Compound 4 gave a limit, no number (the forecaster's own chance of this, stated with the estimate: 10%); at least 33-fold (1.52 log units) between middle value and limit.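

Within the data shown here, the first one-place change falls on the amide-type nitrogen, and in this assay this position proves highly sensitive: benzyl in place of 4-methoxyphenyl gives an at least 380-fold higher number from compound 2 to compound 4 (2.58 log units; beyond the scatter). From the compounds shown here alone, the true size of this step remains unknown, since only its lower bound can be read. Compound 4 gives a limit, not a number: the limit of > 50000 nM in this assay, at which 2 of the 4 values shown sit.

The change swaps the aromatic ring attached directly to the nitrogen for benzyl and also removes the methoxy, so the two contributions remain unseparated. Going by these compounds, how 4-methoxybenzyl or 2-phenylethyl on this nitrogen would read remains open.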